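This account rests on a few compounds, and the source may have more. Where it says the series, first, only, none or still open, it means among the compounds named here.

Compound 1 `CNc1cccc(NC(=O)CN2C(=O)N(CC(=O)C(C)(C)C)c3ccccc3N(C3CCCCC3)C2=O)c1` and compound 2 `CC(C)(C)C(=O)CN1C(=O)N(CC(=O)Nc2cccc(CCC(=O)O)c2)C(=O)N(C2CCCCC2)c2ccccc21` share the tert-butyl ketone side chain; in an assay on CHO-K1 cells for displacement of a labelled ligand from Cholecystokinin receptor type A (Homo sapiens) (on this read-out lower numbers stand for stronger inhibition and higher numbers for weaker inhibition), compound 1 gives 2340 nM and compound 2 gives 2340 nM, so the step of no change at the digits printed from compound 1 to compound 2 (within the scatter) is flat. Compound 3 `Cc1cccc(NC(=O)CN2C(=O)N(CC(=O)N3CCCC3)c3ccccc3N(C3CCCCCC3)C2=O)c1` carries a pyrrolidine amide instead and a cycloheptyl ring; in this assay compound 3 gives 617 nM, the lowest of the three numbers and beyond the scatter from both compound 1 and compound 2.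

Compound 4 `Cc1cccc(NC(=O)CN2C(=O)N(CC(=O)C(C)(C)C)c3ccccc3N(C3CCCCCC3)C2=O)c1` differs from compound 3 by tert-butyl in place of pyrrolidin-1-yl on a carbonyl carbon. Within the data shown here, no measured step touches this carbonyl substituent: the only single-point step, from compound 1 to compound 2, concerns the aromatic substituent. Compounds 1 and 2 do carry the tert-butyl ketone, but they also differ from compound 3 in the ring and aryl group, so their gap to compound 3 cannot be assigned to the ketone alone. The expected step is a 1.1-fold higher number from compound 3 to compound 4 (0.05 log units; within the scatter), small and not clearly beyond the scatter. Compound 4 is estimated at 700 nM, range 250 nM to 2000 nM.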

Compound 4, inhibition constant: 447 nM
For compound 4 the middle estimate is 1.6-fold (0.19 log units) above the measured one; the measured number falls inside the stated range.
By their numbers in this assay, from the lowest: compounds 4 and 3 (each within the scatter of the next); then compounds 1 and 2 (each within the scatter of the next).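

At this carbonyl carbon, this assay now gives a first single-place reading, a 1.4-fold lower number from compound 3 to compound 4 (0.14 log units; within the scatter), and the exchange of pyrrolidin-1-yl for tert-butyl produces no change beyond the scatter. For this one pair, the carbonyl substituent can therefore be either a ring with a nitrogen or an open carbon group with no ring, and compound 3 and compound 4 still read alike. No evidence at hand bears on this result.

Going by these compounds, whether a carboxylic acid, a dimethylamino group or a longer chain on this carbonyl carbon would also leave the number within the scatter remains open. On these data alone, it is also open whether the same exchange would read alike with the aromatic substituents of compound 1 and compound 2.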